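Swapping the amide aryl group: little change expected

The compounds below may be only part of what the source reports. "The series", "measured", "known", "first", "only" and "open" are said of these compounds alone.

Three compounds built on one shared core differ only in the aromatic ring on the amide nitrogen. In an ADME assay on HaCaT cells (Homo sapiens) for inhibition (a higher number here means a weaker inhibitor, a lower number a stronger inhibitor), compound 1 `COc1cc(-c2cc(C(=O)O)c3ccccc3n2)ccc1OCC(=O)Nc1cccc(C)c1` gives 225000 nM, compound 2 `COc1cc(-c2cc(C(=O)O)c3ccccc3n2)ccc1OCC(=O)Nc1cccc(F)c1` gives 148000 nM, and compound 3 `COc1cc(-c2cc(C(=O)O)c3ccccc3n2)ccc1OCC(=O)Nc1ccccc1Cl` gives 210000 nM, the second highest of the three numbers, where a 1.1-fold lower number from compound 1 to compound 3 (0.03 log units; within the scatter) and a 1.4-fold higher number from compound 2 to compound 3 (0.15 log units; within the scatter) both lie within the scatter. Compound 4 `COc1cc(-c2cc(C(=O)O)c3ccccc3n2)ccc1OCC(=O)Nc1ccc(C(F)(F)F)cc1` carries 4-(trifluoromethyl)phenyl in place of 2-chlorophenyl on an amide-type nitrogen. The two earlier exchanges of the aryl group on that nitrogen bear directly on this change, and both were small: a 1.1-fold lower number from compound 1 to compound 3 (0.03 log units; within the scatter) and a 1.4-fold higher number from compound 2 to compound 3 (0.15 log units; within the scatter). The step expected in this assay is therefore a 1.1-fold lower number from compound 3 to compound 4 (0.02 log units; within the scatter), nothing beyond the scatter. Compound 4 is estimated at 200000 nM, with a range from 100000 nM to 400000 nM.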

Compound 4, half-maximal inhibitory concentration: 150000 nM
The estimate for compound 4 lay 1.3-fold (0.12 log units) above the measured number, within the range that was stated.
By their numbers in this assay, from the lowest: compounds 2, 4, 3 and 1 (each within the scatter of the next).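

In this assay the 4-(trifluoromethyl)phenyl group on the amide-type nitrogen stays within the scatter of all three earlier aryl groups, with a 1.4-fold lower number from compound 3 to compound 4 (0.15 log units; within the scatter) and a 1.0-fold higher number from compound 2 to compound 4 (0.01 log units; within the scatter) and also a 1.5-fold lower number from compound 1 to compound 4 (0.18 log units; within the scatter) in this series. Across these four aryl groups, the number therefore does not move beyond the scatter. Nothing available explains this flat result.

Still open, on these data alone, is whether an amine or a carboxylic acid on this aryl ring, or a longer chain in its place, would shift the number beyond the scatter.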